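A few compounds are considered here, and "the series" means these few. Any claim that something is new, unique, unknown or untested is made for them only; others in the source may bear on it.

Three compounds share one core and differ only in the side group that hangs from an amine nitrogen on a saturated chain carbon. Compound 1 `CCCCc1ccc(CN(Cc2ccccc2)S(=O)(=O)c2ccccc2)c(=O)n1Cc1ccc(-c2ccccc2-c2nn[nH]n2)cc1` carries a benzyl and a benzenesulfonyl on that nitrogen; in a functional assay (aorta) for antagonist activity, with Oryctolagus cuniculus as the target (a higher number here means a weaker inhibitor, a lower number a stronger inhibitor), compound 1 gives 20 nM. Compound 2 `CCCCc1ccc(CNC(=O)N(C)C)c(=O)n1Cc1ccc(-c2ccccc2-c2nn[nH]n2)cc1` carries a dimethylcarbamoyl and gives 2 nM. Compound 3 `CCCCc1ccc(CNC(=O)Nc2ccccc2)c(=O)n1Cc1ccc(-c2ccccc2-c2nn[nH]n2)cc1` carries a phenylcarbamoyl and gives 30 nM, the highest of the three numbers, with compound 1 nearest and compound 2 furthest. For the measured compounds named here, the one measured single-point step, a 15-fold higher number from compound 2 to compound 3 (1.18 log units; beyond the scatter), shows that swapping the group on the carbonyl carbon matters a great deal.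

Compound 4 `CCCCc1ccc(CNCc2ccccc2)c(=O)n1Cc1ccc(-c2ccccc2-c2nn[nH]n2)cc1` takes the change (benzyl in place of phenylcarbamoyl on an amine nitrogen). Going by the values given here, no measured step removes the carbonyl itself, so the step from compound 2 to compound 3 bears on it only loosely; compound 1, which also holds a benzyl on that nitrogen, offers a rough anchor. A moderate step from compound 3 is therefore expected, a 1.5-fold lower number from compound 3 to compound 4 (0.18 log units; within the scatter), with direction uncertain. Compound 4 is estimated at 20 nM, between 4 nM and 100 nM.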

Compound 4, half-maximal inhibitory concentration: 1 nM
Compound 4: middle estimate off by 20-fold (1.30 log units), on the high side; measured number outside the range, below it.
By their numbers in this assay, from the lowest: compounds 4 and 2 (each within the scatter of the next); then compounds 1 and 3 (each within the scatter of the next).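

On this amine nitrogen, a carbonyl is not needed for a low number: benzyl in place of phenylcarbamoyl gives a 30-fold lower number from compound 3 to compound 4 (1.48 log units; beyond the scatter), while benzyl in place of dimethylcarbamoyl gives a 2.0-fold lower number from compound 2 to compound 4 (0.30 log units; within the scatter), so these two groups cannot be told apart here. With benzyl kept on the nitrogen, hydrogen in place of phenylsulfonyl gives a 20-fold lower number from compound 1 to compound 4 (1.30 log units; beyond the scatter), so the second group on this nitrogen also matters greatly. Nothing here offers a measured reason for these shifts.

On these data alone, it remains open whether a low number in this assay would survive with a methyl, or with a longer chain such as phenylethyl, in place of the benzyl. A carboxylic acid or a methoxy group on the benzyl ring is equally untested by the compounds shown.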